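The compounds below may be only part of what the source reports. "The series", "measured", "known", "first", "only" and "open" are said of these compounds alone.

Values in a functional assay on MV4-11 cells (Homo sapiens) for antiproliferative activity, read by CellTiter-Glo, with a stated time of 72 h (a higher number here means a weaker inhibitor of growth, a lower number a stronger inhibitor of growth), are as follows.

- Compound 1 `CC(C)(C)OC(=O)Nc1nc(-c2cc(F)ncc2Cl)cs1` gives > 10000 nM as a limit
- Compound 2 `Fc1cc(-c2csc(NCC3CCOCC3)n2)c(Cl)cn1` gives > 10000 nM as a limit
- Compound 3 `N[C@H]1CC[C@H](Nc2cc(-c3csc(NCC4CCOCC4)n3)c(Cl)cn2)CC1` gives 140 nM as a number

Among the measured compounds shown here, compound 3 at 140 nM holds the only exact value so far. The other two values are limits. Compound 4 `CCOCCN[C@H]1CC[C@H](Nc2cc(-c3csc(NCC4CCOCC4)n3)c(Cl)cn2)CC1` carries 2-ethoxyethyl in place of hydrogen on an amine nitrogen of compound 3 (2-ethoxyethyl in place of hydrogen on an amine nitrogen). The step that bears most directly on this is an at least 71-fold lower number from compound 2 to compound 3 (1.85 log units; beyond the scatter) and it brought in the (4-aminocyclohexyl)amino group, which holds that amine. The other step, a step that the two limits leave unreadable from compound 1 to compound 2, gives no size. For the measured compounds named here, no measured step alters this amine itself, so any direction is tentative, but a moderately lower number is expected. The expected change is a 2.8-fold lower number from compound 3 to compound 4 (0.45 log units; beyond the scatter) in this assay and it stays uncertain. Compound 4 is estimated at 50 nM with an expected range of 12 nM to 200 nM in this measurement.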

Compound 4, concentration for 50% growth inhibition: 497 nM
For compound 4 the middle estimate is 9.9-fold (1.00 log units) below the measured one, and the stated range ends below it.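

In this assay, the amine nitrogen of compound 3 can carry a chain without losing activity: 2-ethoxyethyl there gives a 3.6-fold higher number from compound 3 to compound 4 (0.55 log units; beyond the scatter), so growth inhibition weakens only modestly. Among the compounds shown here, this is the first measured change on that amine itself, as earlier steps only brought the amine in. Nothing shown gives a reason for this rise.

A single chain sets no trend. On these data alone, whether methyl, a longer alkyl chain, or a chain ending in a carboxylic acid on this nitrogen would match or beat compound 3 stays open.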